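A few compounds are considered here, and "the series" means these few. Any claim that something is new, unique, unknown or untested is made for them only; others in the source may bear on it.

Measured so far in a functional assay on SNB-78 cells (Homo sapiens) for inhibition, read by sulforhodamine B assay, with a stated time of 48 h; on this read-out higher numbers stand for weaker inhibition of growth and lower numbers for stronger inhibition of growth:
- Compound 1 `CCCCCCCCCCCC[C@@H](O)[C@H]1CC[C@H]([C@H](O)CCCCCCCCCCN(C)C(=O)c2ccnn2C)O1`: 12000 nM
- Compound 2 `CCCCCCCCCCCC[C@@H](O)[C@H]1CC[C@H]([C@H](O)CCCCCCCCCCNCc2ccnn2C)O1`: 2090 nM

Of these two, compound 2 has the lower number, so it inhibits growth more strongly, and compound 1 sits clearly above it. The next compound, compound 3 `CCCCCCCCCCCC[C@@H](O)[C@H]1CC[C@H]([C@H](O)CCCCCCCCCCOC(=O)c2ccnn2C)O1`, puts ((1-methyl-1H-pyrazol-5-yl)carbonyl)oxy in place of ((1-methyl-1H-pyrazol-5-yl)methyl)amino on a saturated chain carbon, ten or more bonds along the chain from an oxygen on a saturated carbon and a saturated ring carbon.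

Among the measured compounds shown here, only one measured step bears on this change, a 5.7-fold lower number from compound 1 to compound 2 (0.76 log units; beyond the scatter). That step removed a carbonyl, and compound 3 brings a carbonyl back at the same place on the chain. The measured step therefore suggests a move in the opposite direction, to a higher number, of similar or somewhat smaller size. For the measured compounds named here, no compound with this exact group has been measured, so the expectation rests on a single comparison.

The expected change is a 2.9-fold higher number from compound 2 to compound 3 (0.46 log units; beyond the scatter). For compound 3 the estimated value is 6000 nM, with an expected range from 2000 nM to 18000 nM.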

Compound 3, concentration for 50% growth inhibition: 44700 nM
Compound 3: the middle estimate sits 7.5-fold (0.87 log units) below what was measured, and the stated range ends below it.
By their numbers in this assay, from the lowest: compound 2; then compound 1; then compound 3.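

In this assay, putting ((1-methyl-1H-pyrazol-5-yl)carbonyl)oxy in place of ((1-methyl-1H-pyrazol-5-yl)methyl)amino gives a 21-fold higher number from compound 2 to compound 3 (1.33 log units; beyond the scatter) and is the largest step among these three compounds, so the number depends strongly on how the five-membered aromatic ring is attached to the end of the chain. The carbonyl alone does not set the number: compound 1 and compound 3 both carry it, yet exchanging methyl((1-methyl-1H-pyrazol-5-yl)carbonyl)amino for ((1-methyl-1H-pyrazol-5-yl)carbonyl)oxy gives a 3.7-fold higher number from compound 1 to compound 3 (0.57 log units; beyond the scatter) and shows that the atom joining the carbonyl to the chain also matters. Nothing available here explains these differences.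

The compounds shown leave open whether the methyl on the nitrogen of compound 1 contributes to its number, which the ((1-methyl-1H-pyrazol-5-yl)carbonyl)amino group, carrying the amide hydrogen instead, would address. They also do not separate the carbonyl from the oxygen in compound 3, and the ether ((1-methyl-1H-pyrazol-5-yl)methyl)oxy would allow a comparison of oxygen with nitrogen in compound 2 with no carbonyl present.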